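Benzyl ether in place of isopentyl ether

This account rests on a few compounds, and the source may have more. Where it says the series, first, only, none or still open, it means among the compounds named here.

Compound 1 `CC(C)CCOc1cccc2occ(Cc3coc4ccccc4c3=O)c(=O)c12` carries an isopentyloxy group on the shared core. In a functional assay on NCI-H23 cells (Homo sapiens) for antiproliferative activity, read by XTT assay (a lower number here means a stronger inhibitor, a higher number a weaker inhibitor), compound 1 gives only a limit, > 10000 nM, and so its standing among the measured compounds is not fixed by a number; it sits at the limit of > 10000 nM in this assay, at which 1 of the 3 values shown sits. Compound 2 `Cc1ccc2c(=O)c(Cc3coc4cccc(OCC5CCCCC5)c4c3=O)coc2c1` gives 3220 nM in this assay, and compound 3 `O=c1c(Cc2coc3cccc(OCC4CCCCC4)c3c2=O)coc2cc(O)ccc12` gives 2150 nM; the step of a 1.5-fold lower number from compound 2 to compound 3 (0.18 log units; within the scatter) lies within the scatter. Compound 4 `O=c1c(Cc2coc3cccc(OCc4ccccc4)c3c2=O)coc2ccccc12` differs from compound 1 by phenyl in place of isobutyl on a saturated chain carbon bound to an oxygen on an aromatic ring. For the measured compounds named here, no measured step covers this exchange directly; compounds 2 and 3 differ from compound 1 in more than one place, and their values show only that compounds with a ring in the ether chain have been reported with numbers rather than limits. Compound 4 is therefore expected to come in near 5000 nM, with a range from 1500 nM to 20000 nM. The step of an at least 2.0-fold lower number from compound 1 to compound 4 (0.30 log units; that floor lies within the scatter) is expected, though a limit instead of a number remains possible.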

Compound 4, half-maximal inhibitory concentration: > 10000 nM
Compound 4 gave a limit, no number (the forecaster's own chance of this, stated with the estimate: 35%); at least 2.0-fold (0.30 log units) between middle value and limit.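

For the compounds shown here, compound 1 and compound 4 both give limits rather than numbers, so no step between them can be read: the limit of > 10000 nM in this assay, at which 2 of the 4 values shown sit. The compounds shown leave open whether benzyloxy in place of isopentyloxy changes the activity at all and, if it does, in which direction and by how much.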